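Catechol diether amides: anilide to thiazolyl amide

This account rests on a few compounds, and the source may have more. Where it says the series, first, only, none or still open, it means among the compounds named here.

Measured so far:
- compound 1 `COc1ccc(C(=O)Nc2ccccc2Br)cc1OC1CCCC1` — 130 nM
- compound 2 `COc1ccc(C(=O)Nc2c(F)cccc2F)cc1OC1CCCC1` — 70 nM
- compound 3 `COc1ccc(C(=O)Nc2ccccc2O)cc1OC1CCCC1` — 1300 nM

All three share one core and differ only in the aryl group on the amide nitrogen, read in an assay on isolated protein for inhibition of phosphodiesterase 4A (Sus scrofa); on this read-out lower numbers stand for stronger inhibition and higher numbers for weaker inhibition. Compound 3 gives the highest number of the three: a 10-fold higher number from compound 1 to compound 3 (1.00 log units; beyond the scatter), and a 19-fold higher number from compound 2 to compound 3 (1.27 log units; beyond the scatter). Compounds 1 and 2 lie within the scatter of each other, a 1.9-fold lower number from compound 1 to compound 2 (0.27 log units; within the scatter), so the spread of the set rests on the 2-hydroxyphenyl of compound 3 alone.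

Compound 4 `COc1ccc(C(=O)Nc2nccs2)cc1OC1CCCC1` is not yet measured. The change from compound 3 is 1,3-thiazol-2-yl in place of 2-hydroxyphenyl on an amide-type nitrogen. Within the data shown here, no measured step swaps the aryl ring for a five-membered heteroaryl, so the nearest guide is the pair of steps that leave the 2-hydroxyphenyl behind: a 10-fold higher number from compound 1 to compound 3 (1.00 log units; beyond the scatter) and a 19-fold higher number from compound 2 to compound 3 (1.27 log units; beyond the scatter), both beyond the scatter and both pointing to compound 3 as the outlier. Leaving that group is therefore expected to move the number back toward the range of compounds 1 and 2 in this assay, a step of about an 8.7-fold lower number from compound 3 to compound 4 (0.94 log units; beyond the scatter), though the heteroaryl itself is untested and the range is kept wide. The estimate for compound 4 in this assay is 150 nM, between 40 nM and 600 nM.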

Compound 4, half-maximal inhibitory concentration: 6500 nM
Beside the measured number, compound 4's estimate is 43-fold (1.64 log units) below it; measured number above the stated range.
By their numbers in this assay, from the lowest: compounds 2 and 1 (each within the scatter of the next); then compound 3; then compound 4.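

In this assay, among these compounds, 1,3-thiazol-2-yl in place of 2-hydroxyphenyl on the amide-type nitrogen does not bring the number back toward the other compounds, but moves it further away (a 5.0-fold higher number from compound 3 to compound 4 (0.70 log units; beyond the scatter)), so compound 3 is no longer the only compound with a weak number and compound 4 now marks the weak end of the set. Against the two halogen-bearing aryl groups the gap is wider still (a 50-fold higher number from compound 1 to compound 4 (1.70 log units; beyond the scatter); a 93-fold higher number from compound 2 to compound 4 (1.97 log units; beyond the scatter)), which makes this position far more sensitive to the choice of ring than the within-scatter pair of compound 1 and compound 2 suggested. Nothing available here accounts for this loss.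

Still open, as far as these compounds go, is whether the loss belongs to the five-membered ring as such or to 1,3-thiazol-2-yl in particular, a question that an oxazolyl, a pyridyl or a plain phenyl on the same nitrogen would help to settle. Also open, from the compounds shown here alone, is whether a methoxy in place of the hydroxy of compound 3 would keep that compound's weak number or return it to the range of compound 1.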